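Bis(trifluoromethyl)benzenesulfonamides: aryl swap on the amine side

The source may report more compounds than this note shows. Statements on the series, on what has been measured and on what is new or still open speak of the compounds shown alone.

Measured so far:
- compound 1 `COc1ccc(CNCCCNS(=O)(=O)c2cc(C(F)(F)F)cc(C(F)(F)F)c2)cc1OC`: 15000 nM
- compound 2 `O=S(=O)(NCCCNCc1cccc2ccccc12)c1cc(C(F)(F)F)cc(C(F)(F)F)c1`: 2700 nM

Both compounds were tested in a functional assay on Capan-2 cells (Homo sapiens) for inhibition, read by MTT assay, with a stated time of 72 h; on this read-out lower numbers stand for stronger inhibition of growth and higher numbers for weaker inhibition of growth. Going by the values given here, compound 2 gives the lowest of the two numbers; its nearest neighbour is compound 1, and the only measured step, a 5.6-fold lower number from compound 1 to compound 2 (0.74 log units; beyond the scatter), is beyond the scatter and concerns the aryl group on the saturated chain carbon bound to the amine nitrogen.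

Compound 3 `O=S(=O)(NCCCNCc1cccc(Cl)c1)c1cc(C(F)(F)F)cc(C(F)(F)F)c1` is the next member. Its change from compound 2 is 3-chlorophenyl in place of naphthalen-1-yl on a saturated chain carbon bound to an amine nitrogen. This is the same position that moved in the step from compound 1 to compound 2, so that step is the only one that bears on it; it shows that the aryl group here can shift the number by a modest amount. Among the compounds with values here, no measured pair shows a naphthalen-1-yl to 3-chlorophenyl exchange directly, so the direction is open. A single six-membered ring with one chlorine is expected to sit somewhere between the two measured aryl groups, closer to compound 2 than to compound 1; for compound 3 the estimate in this assay is therefore 5000 nM, range 1500 nM to 16000 nM, a step of a 1.9-fold higher number from compound 2 to compound 3 (0.27 log units; within the scatter).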

Compound 3, concentration for 50% growth inhibition: 8000 nM
Compound 3: middle estimate off by 1.6-fold (0.20 log units), on the low side; measured number inside the range.
By their numbers in this assay, from the lowest: compound 2; then compounds 3 and 1 (each within the scatter of the next).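

In this assay, 3-chlorophenyl in place of naphthalen-1-yl gives a 3.0-fold higher number from compound 2 to compound 3 (0.47 log units; beyond the scatter), so compound 2 now holds the lowest number against two single-ring aryl groups, each step to it lying beyond the scatter. Against the other single-ring group, 3-chlorophenyl in place of 3,4-dimethoxyphenyl gives a 1.9-fold lower number from compound 1 to compound 3 (0.27 log units; within the scatter), which lies within the scatter, so compound 1 and compound 3 cannot be ordered and the chlorine and the two methoxy groups are not told apart at this position. No supporting data are at hand to explain the difference between the two-ring group and the single-ring groups.

Three aryl groups cannot show whether the lower number of compound 2 goes with naphthalen-1-yl specifically or with two fused aromatic rings in general, and naphthalen-2-yl, quinolin-4-yl or plain phenyl on the same saturated chain carbon would bear on that question. The series also leaves open how this aryl ranking holds up with a longer chain between the two nitrogens or with an amide in place of the amine, since all three compounds share the same core and chain.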